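The source may hold more compounds than are shown below. What is called first, only, known or untested is meant among the compounds shown, and "the series" means these compounds.

Compound 2 `Cc1cc2nc(NC(c3cn(-c4ccccc4)nc3-c3ccc([N+](=O)[O-])cc3)c3c(O)ccc4ccccc34)sc2cc1C` gives 14700 nM in a functional assay on HeLa cells (Homo sapiens) for antiproliferative activity, read by MTT assay, with a stated time of 48 h; a lower number here means a stronger inhibitor, a higher number a weaker inhibitor. Among the three compounds measured it stands second highest: compound 1 `Cc1ccc(-c2nn(-c3ccccc3)cc2C(Nc2nc3cc(C)c(C)cc3s2)c2c(O)ccc3ccccc23)cc1` gives 17800 nM, and compound 3 `Cc1cccc(-c2nn(-c3ccccc3)cc2C(Nc2nc3ccccc3s2)c2c(O)ccc3ccccc23)c1` gives 7020 nM. The gap from compound 2 to compound 1 lies within the scatter, while the gap from compound 2 to compound 3 lies beyond it, compound 3 giving the lower number.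

For the measured compounds named here, compound 4 `O=[N+]([O-])c1ccc(-c2nn(-c3ccccc3)cc2C(Nc2nc3ccc(Cl)cc3s2)c2c(O)ccc3ccccc23)cc1` differs from compound 2 in one place: 6-chloro-1,3-benzothiazol-2-yl in place of 5,6-dimethyl-1,3-benzothiazol-2-yl on an amine nitrogen The only measured single-place step, a 1.2-fold lower number from compound 1 to compound 2 (0.08 log units; within the scatter), concerns a different part of the molecule and does not touch the group on the amine nitrogen. Compounds 1 and 3 differ from each other in two places, so their values cannot be read as a step for this change; they merely show that the shared core tolerates both benzothiazole substitution patterns at a similar level. Nothing measured therefore points to a change beyond the scatter. Compound 4 is expected near 12000 nM, between 5000 nM and 30000 nM, a step of a 1.2-fold lower number from compound 2 to compound 4 (0.09 log units; within the scatter).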

Compound 4, half-maximal inhibitory concentration: 13400 nM
Compound 4: middle estimate off by 1.1-fold (0.05 log units), on the low side; low and high end bracket the measured number.
By their numbers in this assay, from the lowest: compounds 3, 4, 2 and 1 (each within the scatter of the next, the first and the last beyond it).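

In this assay, 6-chloro-1,3-benzothiazol-2-yl can take the place of 5,6-dimethyl-1,3-benzothiazol-2-yl on the amine nitrogen with a 1.1-fold lower number from compound 2 to compound 4 (0.04 log units; within the scatter) and no departure beyond the scatter. For the compounds shown here, this is the first reading at this position from a pair that differs in one place only, and it shows that, with the nitro group present in both compounds, this exchange of benzothiazole groups leaves the number at the same level. No measurement shown offers an explanation for this result.

Going by these compounds, it remains open whether a benzothiazole carrying an amine or a carboxylic acid instead of the chlorine would hold this level or leave it. Also open, on these data alone, is whether the same exchange would read alike in compounds with methyl instead of nitro on the aromatic carbon.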